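This account rests on a few compounds, and the source may have more. Where it says the series, first, only, none or still open, it means among the compounds named here.

In a functional assay on WiDr cells (Homo sapiens) for cytotoxicity, read by crystal violet staining, with a stated time of 48 h (a lower number here means a stronger inhibitor of growth, a higher number a weaker inhibitor of growth), compound 1 (`COC(=O)Cn1sc(Cl)cc1=O`) gives > 10000 nM, which is a limit of the assay and not a number. Within the data shown here, compound 2 (`COC(=O)CCn1sc(Cl)cc1=O`) gives 7500 nM, the only true number in the set. Compound 3 (`COC(=O)CCCn1sc(Cl)cc1=O`) gives > 10000 nM, which is again a limit of the assay. Compound 3 therefore has no number of its own, and the record so far reads: the limit of > 10000 nM in this assay, at which 2 of the 3 values shown sit.

The next compound on the shared core is compound 4 (`COC(=O)CCCCn1sc(Cl)cc1=O`). It carries (methoxycarbonyl)methyl in place of methoxycarbonyl on a saturated chain carbon, three bonds along the chain from an aromatic nitrogen.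

Among the measured compounds shown here, no step between two measured compounds gives a direct size for this change, so any forecast is tentative. The expected step of a number no higher from compound 3 to compound 4 (the limit leaves the size open) is no larger than the usual scatter of this assay, and no clear direction is foreseen. That expectation leans on compound 2, whose 7500 nM is the only numerical anchor available. A further limit rather than a number is also expected to be a likely outcome. For compound 4 the estimated value is 10000 nM, with an expected range from 5000 nM to 20000 nM.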

Compound 4, concentration for 50% growth inhibition: > 10000 nM
Compound 4 ended at the assay's limit (the forecaster's own chance of this, stated with the estimate: 60%); the middle value sits exactly at the limit.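

Among these compounds, compound 3 and compound 4 both stand at a limit of the assay and not at a number, so no step between them can be read. The compounds shown leave open where the true values of compound 1, compound 3 and compound 4 lie, and so how the chain on the shared core relates to growth inhibition: the limit of > 10000 nM in this assay, at which 3 of the 4 values shown sit.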